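Amine substituent variation on the shared core: compound 4

The compounds below may be only part of what the source reports. "The series", "measured", "known", "first", "only" and "open" are said of these compounds alone.

Three compounds carry the same core. Compound 1 `CCCCC(=O)Nc1ncc(-c2cccc(Cl)c2)c(-c2ccccc2)n1` gives 52% in an assay on CHO cells for displacement of a labelled ligand from adenosine receptor A1 (Homo sapiens), read by scintillation counting, with a stated time of 1 h, tested at 1 uM; a lower number here means less inhibition, a higher number more inhibition at the concentration tested (going by the name of the read-out). Compound 2 `O=C(Nc1ncc(-c2cccc(Cl)c2)c(-c2ccccc2)n1)C1CCC1` gives 52% in this assay, and the step of no change at the digits printed from compound 1 to compound 2 (within the scatter) shows that exchanging one acyl group for another of similar size leaves the read-out unchanged. Compound 3 `CC(C)Nc1ncc(-c2cccc(Cl)c2)c(-c2ccccc2)n1` gives 71% in this assay and stands highest of the three numbers, with the steps of a number 19 percentage points higher from compound 1 to compound 3 (beyond the scatter) and a number 19 percentage points higher from compound 2 to compound 3 (beyond the scatter) both beyond the scatter, so the inhibition in this assay is highest for compound 3 among the measured set.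

Compound 4 `Clc1cccc(-c2cnc(NCCCc3ccccc3)nc2-c2ccccc2)c1` is not yet measured. It differs from compound 3 by 3-phenylpropyl in place of isopropyl on a nitrogen on an aromatic ring. For the measured compounds named here, no measured step alters the group on the ring nitrogen while keeping the amine; the only step within one class, no change at the digits printed from compound 1 to compound 2 (within the scatter), was flat. Going by the values given here, the steps that bear on compound 4 therefore show that the amine versus carbonyl distinction mattered, whereas a change of the alkyl part alone did not. The expectation for compound 4 is a step of a number 3 percentage points lower from compound 3 to compound 4 (within the scatter) that is small and within the scatter, with some downward allowance for the larger group. Compound 4 is estimated at 68%, in the range 48% to 86%.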

Compound 4, a percentage reported as inhibition, at one concentration (the size of the read-out at that concentration, not a potency): 33%
Beside the measured number, compound 4's estimate is 35 percentage points above it; measured number below the stated range.
By their numbers in this assay, from the lowest: compound 4; then compounds 1 and 2 (each within the scatter of the next); then compound 3.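

In this assay the group on the nitrogen matters even when the amine is kept: 3-phenylpropyl in place of isopropyl gives a number 38 percentage points lower from compound 3 to compound 4 (beyond the scatter), so the flat result between the acyl groups of compound 1 and compound 2 does not extend to this amine pair. Compound 4 also stands under both amides, with a number 19 percentage points lower from compound 2 to compound 4 (beyond the scatter) and a number 19 percentage points lower from compound 1 to compound 4 (beyond the scatter), so the higher number for the amine over the carbonyl compounds holds for compound 3 only, and compound 4 goes against it. Nothing available gives a reason for this drop.

The entering group differs from isopropyl both in its count of carbon atoms and in its six-membered aromatic ring, and the compounds shown do not separate these two changes. A benzyl group, an unbranched propyl chain or a 3-cyclohexylpropyl group on the same nitrogen would help to tell whether the chain length or the terminal phenyl ring goes with the lower number.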